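Butyl sulfonate series: from bromophenyl to dimethoxyphenyl

The source may report more compounds than this note shows. Statements on the series, on what has been measured and on what is new or still open speak of the compounds shown alone.

Measured so far in a functional assay on M21 cells (Homo sapiens) for antiproliferative activity, read by sulforhodamine B assay, with a stated time of 48 h; a lower number here means a stronger inhibitor, a higher number a weaker inhibitor:
- Compound 1 `COc1ccc(OS(=O)(=O)c2ccc(N3CCN(C)C3=O)cc2)cc1OC`: 8500 nM
- Compound 2 `CCCCN1CCN(c2ccc(S(=O)(=O)Oc3cccc(OC)c3)cc2)C1=O`: 30000 nM
- Compound 3 `CCCCN1CCN(c2ccc(S(=O)(=O)Oc3cccc(Br)c3)cc2)C1=O`: 35000 nM

Compound 3 at 35000 nM stands within the scatter of compound 2 at 30000 nM. Compound 1 at 8500 nM gives a lower number than either.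

The next change leads to compound 4 `CCCCN1CCN(c2ccc(S(=O)(=O)Oc3ccc(OC)c(OC)c3)cc2)C1=O`, with 3,4-dimethoxyphenyl in place of 3-bromophenyl on an oxygen.

For the measured compounds named here, only one measured step involves a single change on this aromatic ring. Bromo in place of methoxy on an aromatic carbon gives a 1.2-fold higher number from compound 2 to compound 3 (0.07 log units; within the scatter), which lies within the scatter. Taken alone, that step points to little movement. However, it does not test a second methoxy group. Going by the values given here, the only measured compound carrying 3,4-dimethoxyphenyl is compound 1 at 8500 nM, and it also differs from compound 4 elsewhere on the shared core. Among the compounds with values here, its value therefore supports only a partial shift towards a lower number, and no measured step isolates the contribution of the aromatic group.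

An estimated 2.5-fold lower number from compound 3 to compound 4 (0.40 log units; beyond the scatter) is expected in this assay, a modest step with a real chance of staying within the scatter.

Compound 4 is expected at 14000 nM, with an estimated range of 5000 nM to 35000 nM.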

Compound 4, half-maximal inhibitory concentration: > 100000 nM
Compound 4 ended at the assay's limit (the forecaster's own chance of this, stated with the estimate: 10%); at least 7.1-fold (0.85 log units) between middle value and limit.
By their numbers in this assay, from the lowest: compound 1; then compounds 2 and 3 (each within the scatter of the next). At a limit, above all of these: compound 4.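

In this assay, compound 4 stands at a limit and not at a measured number: the limit of > 100000 nM in this assay, at which 1 of the 4 values shown sits.

For the compounds shown here, the aromatic group on the oxygen bound to the sulfonyl sulfur matters more than a 1.2-fold higher number from compound 2 to compound 3 (0.07 log units; within the scatter) suggested: with the butyl chain in place, adding a second methoxy gives an at least 3.3-fold higher number from compound 2 to compound 4 (0.52 log units; beyond the scatter), and replacing 3-bromophenyl with 3,4-dimethoxyphenyl gives an at least 2.8-fold higher number from compound 3 to compound 4 (0.45 log units; beyond the scatter), so this position is not as flat as the single bromo and methoxy exchange implied. Going by these compounds alone, with 3,4-dimethoxyphenyl held fixed, the chain on the ring nitrogen also proves to be a large lever, since propyl in place of hydrogen on that chain gives an at least 11-fold higher number from compound 1 to compound 4 (1.07 log units; beyond the scatter), a comparison that isolates the chain for the first time.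

The compounds shown leave open whether the chain effect is graded, as an ethyl or a propyl chain on the ring nitrogen would show, and whether it also holds with 3-methoxyphenyl or 3-bromophenyl on the oxygen. They also leave open how a hydroxyl, an amine or a fluoro group on this aromatic ring would read with the methyl chain of compound 1.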